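This account rests on a few compounds, and the source may have more. Where it says the series, first, only, none or still open, it means among the compounds named here.

Compound 2 `COc1cccc(C(=O)Nc2ccc(NC(=O)c3csnn3)cc2)c1` is the starting point of this step. In an ADME assay on MRC5 cells (Homo sapiens) for cytotoxicity (on this read-out higher numbers stand for lower toxicity in this test and lower numbers for higher toxicity in this test), compound 2 gives only a limit, > 57000 nM. Compound 1 `COc1cccc(C(=O)Nc2ccc(NC(=O)c3cscn3)cc2)c1` likewise gives only a limit in this assay, namely > 57000 nM. Among the compounds with values here, the one measured step, a step that the two limits leave unreadable from compound 1 to compound 2, cannot be sized, since both values sit at the limit of > 57000 nM in this assay, at which 2 of the 2 values shown sit. Compound 3 `COc1cccc(C(=O)Nc2ccc(NC(=O)c3cncnc3)cc2)c1` differs from compound 2 by pyrimidin-5-yl in place of 1,2,3-thiadiazol-4-yl on a carbonyl carbon. Within the data shown here, no measured step covers this exchange, and the only guide is that both measured compounds rest at the limit. Compound 3 is expected to show no step beyond the scatter, a step that the limit leaves unreadable from compound 2 to compound 3. For compound 3 the estimated value in this assay is 80000 nM, with a range from 30000 nM to 200000 nM.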

Compound 3, half-maximal cytotoxic concentration: > 57000 nM
Compound 3 was reported as a limit; the forecaster's own chance of this, stated with the estimate: 80%; the middle value does not contradict the limit.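

No step can be read between compound 1, compound 2 and compound 3 in this assay, since all three rest at the same limit: the limit of > 57000 nM in this assay, at which 3 of the 3 values shown sit.

The compounds shown leave open how these three exchanged groups truly compare in this read-out.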